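The compounds below may be only part of what the source reports. "The series", "measured", "known", "first", "only" and "open" are said of these compounds alone.

Of the compounds shown here, two of a shared core have been measured in a physicochemical assay for lipophilicity, read by LC-MS, in phosphate buffer, measured as octanol-water partition, with a stated time of 30 min, at pH 7.4, tested at 200 mM; on this read-out higher numbers stand for higher lipophilicity and lower numbers for lower lipophilicity. Compound 1 `Cn1c(COc2cccc(C(=O)O)c2)nc2ccc(Oc3ccc(Cl)c(F)c3)nc21` gives 2.2 in this assay, and compound 2 `Cn1c(COc2cccc(C(=O)O)c2)nc2ccc(Oc3ccccn3)cc21` gives 0.4, which is the lower of the two numbers. Going by the values given here, the two values stand apart from each other by more than the scatter of the measurement, so compound 2 is the less lipophilic of the pair, with compound 1 the only other point of comparison.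

Compound 3 `Cn1c(COc2cccc(C(=O)O)c2)nc2ccc(Oc3ncc(Cl)cc3Cl)cc21` has not yet been measured in this assay. It differs from compound 2 in one place: 3,5-dichloropyridin-2-yl in place of pyridin-2-yl on an oxygen on an aromatic ring. Two chlorine atoms enter on the ring that sits on the ether oxygen, and the count of hydrogen-bond donors and acceptors does not change.

Among the compounds with values here, no step between two measured compounds follows this exact change, so the expectation rests on the general picture. The step from compound 2 to compound 3 in this assay is expected to be upward and well beyond the scatter, at about a number 1.30 log units higher from compound 2 to compound 3 (beyond the scatter). Compound 3 is therefore estimated at 1.7, with a range from 1.2 to 2.3.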

Compound 3, distribution coefficient: 1.9
Compound 3: middle estimate off by 0.20 log units, on the low side, and the stated range covers the measured number.
By their numbers in this assay, from the lowest: compound 2; then compounds 3 and 1 (each within the scatter of the next).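

In this assay, going by these compounds alone, 3,5-dichloropyridin-2-yl in place of pyridin-2-yl on an oxygen on an aromatic ring gives a number 1.50 log units higher from compound 2 to compound 3 (beyond the scatter) and so provides the first step in this set that can be read at a single place. Compound 1 and compound 2 differ in more than one place, so their gap could not be tied to any one part of the structure, whereas this step belongs to this position alone. It also arises with the count of hydrogen-bond donors and acceptors unchanged, so the size of the step at this position does not go along with a change in that count. The compounds shown offer no measurement that accounts for the size of this step.

On these data alone, since both chlorine atoms enter together, the share of each in the step remains open, as does the result of a single chlorine on the pyridin-2-yl ring. Also open, as far as these compounds go, is how a nitrile, a methoxy group or an amine on that ring would read in this assay and whether the same change would give a similar step on another core.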